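The compounds below may be only part of what the source reports. "The series", "measured", "known", "first", "only" and "open" are said of these compounds alone.

Measured so far:
Compound 1 `CC(=O)OC[C@H]1O[C@@H](Oc2nc(-c3cccs3)cc(-c3ccc(Cl)cc3)c2C#N)[C@H](OC(C)=O)[C@@H](OC(C)=O)[C@H]1OC(C)=O` — 0%
Compound 2 `CC(=O)OC[C@H]1O[C@@H](Oc2nc(-c3cccs3)cc(-c3ccc(Cl)cc3)c2C#N)[C@H](OC(C)=O)[C@H]1OC(C)=O` — 0%

In a functional assay on MCF7 cells (Homo sapiens) for inhibition, read by MTT assay, with a stated time of 48 h, tested at 25 ug/mL (a lower number here means a weaker effect, a higher number a stronger effect of the compound at the concentration tested), compound 1 gives 0%. Compound 2 gives 0% in this assay. Compound 1 thus stands level with compound 2 at the digits shown; no step between the two is counted, and their values show no difference beyond the scatter. Neither measured compound shows any inhibition at the concentration tested.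

Compound 3 `CC(=O)OC[C@H]1O[C@@H](Oc2nc(-c3cccs3)cc(-c3ccc(Cl)cc3)c2C#N)[C@H](OC(C)=O)[C@@H](OC(C)=O)[C@@H]1OC(C)=O` has not yet been measured in this assay. It differs from compound 1 as follows: the two compounds have the same atoms and bonds and differ only in configuration as drawn: 1 of 5 stereo elements differ; a stereocentre at a saturated ring carbon is drawn S in compound 1 and R in compound 3. Among the compounds with values here, no step between measured compounds describes a change of configuration at a saturated ring carbon, so the size of such a step cannot be read from the data. Because compound 1 gives 0% and compound 2 gives 0%, both showing no inhibition, the expectation for compound 3 is no change beyond the scatter in this assay. The expected step of a number 2 percentage points higher from compound 1 to compound 3 (within the scatter) is therefore none beyond the scatter. Compound 3 is estimated at 2%, with a range from 0% to 12%.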

Compound 3, a percentage reported as inhibition, at one concentration (the size of the read-out at that concentration, not a potency): 0%
Beside the measured number, compound 3's estimate is 2 percentage points above it; the measured number falls inside the stated range.
By their numbers in this assay, from the lowest: compounds 1, 2 and 3 (each within the scatter of the next).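

In this assay, within the data shown here, the switch of one stereocentre at a saturated ring carbon from S to R gives no change at the digits printed from compound 1 to compound 3 (within the scatter), the first step that tests configuration at this position. With compound 3 at 0%, this inversion does not bring out any inhibition at the concentration tested, and the reading can be tied to this single change: the fact that compounds 1 and 3 differ only in the configuration as drawn.

Since compound 1 and compound 3 both show no inhibition, the step cannot say whether configuration at this carbon would matter in a compound that does inhibit. Also open, going by these compounds, is whether free hydroxyl groups in place of the acetate esters, or a carboxylic acid or an amine in place of the nitrile, would give any inhibition in this assay.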